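A few compounds are considered here, and "the series" means these few. Any claim that something is new, unique, unknown or untested is made for them only; others in the source may bear on it.

Compound 1 `Cc1nc(C)c([C@H](OC(C)(C)C)C(=O)O)c(N2CCC(C)(C)CC2)c1-c1ccc(-c2ccccc2)cc1`: >= 20000 nM
Compound 2 `COc1ccc(CCOc2ccc(-c3c(C)nc(C)c([C@H](OC(C)(C)C)C(=O)O)c3N3CCC(C)(C)CC3)cc2)cc1`: >= 33500 nM
Compound 3 `Cc1nc(C)c([C@H](OC(C)(C)C)C(=O)O)c(N2CCC(C)(C)CC2)c1-c1ccc(OCCc2ccc(F)c(F)c2)cc1`: >= 33500 nM

In a toxicity assay on MT2 cells (Homo sapiens) for cytotoxicity, read by XTT assay, with a stated time of 4 days (a higher number here means that more compound is tolerated, a lower number that less compound is tolerated), compound 1 gives >= 20000 nM, which is a limit of the assay rather than a number. Compound 2 gives >= 33500 nM, again only a limit. Compound 3 likewise gives >= 33500 nM, a limit. So compound 2 stands at a limit, and the two other values shown are limits as well: the limit of >= 20000 nM in this assay, at which 1 of the 3 values shown sits, and (the limit of >= 33500 nM in this assay, at which 2 of the 3 values shown sit). The steps among the measured compounds are therefore not readable: a step that the two limits leave unreadable from compound 1 to compound 2, a step that the two limits leave unreadable from compound 1 to compound 3 and a step that the two limits leave unreadable from compound 2 to compound 3 give no size.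

Compound 4 `Cc1nc(C)c([C@H](OC(C)(C)C)C(=O)O)c(N2CCC(C)(C)CC2)c1-c1ccc(CCCc2ccc(F)cc2)cc1` is not yet measured. It differs from compound 2 as follows: 3-(4-fluorophenyl)propyl in place of 2-(4-methoxyphenyl)ethoxy on an aromatic carbon. For the measured compounds named here, none of the measured steps gives a readable size, so no direction beyond the scatter can be expected for compound 4; what the three limits suggest is that compound 4 will most likely also be tolerated up to the limit, and the step from compound 2 to compound 4 is expected to be a number no higher from compound 2 to compound 4 (the limit leaves the size open). Compound 4 is therefore estimated at 33500 nM, within 15000 nM to 60000 nM.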

Compound 4, half-maximal cytotoxic concentration: >= 32000 nM
Compound 4 was reported as a limit (the forecaster's own chance of this, stated with the estimate: 80%); the middle value lies beyond the limit too.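

In this assay compound 4 gives >= 32000 nM, which is a limit of the assay and not a number. For the compounds shown here, the values of compound 1, compound 2 and compound 3 are limits too, so no step involving compound 4 can be read. The compounds shown leave open the concentration at which any of them harms these cells.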